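The source may hold more compounds than are shown below. What is called first, only, known or untested is meant among the compounds shown, and "the series" means these compounds.

Compounds measured so far:

Compound 1, `CCOC(=O)C1=Cc2ccccc2OC1(OCc1cn(-c2ccccc2)nn1)C(F)(F)F`, in a functional assay on MCF7 cells (Homo sapiens) for inhibition, read by MTT assay, with a stated time of 24 h (on this read-out lower numbers stand for stronger inhibition and higher numbers for weaker inhibition), gives > 150000 nM.
Compound 2, `CCOC(=O)C1=Cc2ccccc2OC1(OCc1cn(CC(=O)Nc2ccc(I)cc2Cl)nn1)C(F)(F)F`, in this assay gives 28100 nM.

The value given for compound 1 is a limit of the assay, not a number; it is the limit of > 150000 nM in this assay, at which 1 of the 2 values shown sits. Within the data shown here, compound 2 therefore stands as the only compound with a measured number in this assay. Among the measured compounds shown here, the one measured step, an at least 5.3-fold lower number from compound 1 to compound 2 (0.72 log units; beyond the scatter), runs from that limit to this number and concerns the group on the aromatic nitrogen.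

Compound 3, `CCOC(=O)C1=Cc2ccccc2OC1(OCc1cn(CC(=O)Nc2ccc(OC)cc2)nn1)C(F)(F)F`, is not yet measured. It differs from compound 2 in this way: 4-methoxyphenyl in place of 2-chloro-4-iodophenyl on an amide-type nitrogen. For the measured compounds named here, no measured step touches the amide-type nitrogen, and the step of an at least 5.3-fold lower number from compound 1 to compound 2 (0.72 log units; beyond the scatter) concerns only the group on the aromatic nitrogen. Compound 3 shares with compound 2 the carbamoylmethyl arm that brought the number down. With nothing shown for the aromatic ring on that arm, the author expects compound 3 to keep a number near that of compound 2, with a small estimated step of a 1.8-fold higher number from compound 2 to compound 3 (0.25 log units; within the scatter). The estimate for compound 3 in this assay is 50000 nM, with a range from 15000 nM to 150000 nM.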

Compound 3, half-maximal inhibitory concentration: 28100 nM
Compound 3: middle estimate off by 1.8-fold (0.25 log units), on the high side; the measured number falls inside the stated range.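

In this assay, 4-methoxyphenyl in place of 2-chloro-4-iodophenyl on the amide-type nitrogen brings no change at the digits printed from compound 2 to compound 3 (within the scatter), so the chlorine and iodine of compound 2 are not needed at this place to keep its number. The ((4-methoxyphenyl)carbamoyl)methyl group in place of phenyl on the aromatic nitrogen gives an at least 5.3-fold lower number from compound 1 to compound 3 (0.72 log units; beyond the scatter), which means that the step seen earlier now holds with two different rings at the end of the arm. The value of compound 1 is a limit of the assay and not a number: the limit of > 150000 nM in this assay, at which 1 of the 3 values shown sits.

Two substituted phenyl rings cannot show whether the ring on the amide-type nitrogen matters at all, and an unsubstituted phenyl, a pyridine or a cyclohexyl at this place would test that. Going by these compounds, it also remains open whether the number depends on the amide itself, which a carboxylic acid or a plain alkyl chain on the aromatic nitrogen in place of the carbamoylmethyl arm would address.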